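From chloro to trifluoromethyl in an antiproliferative series

The compounds below may be only part of what the source reports. "The series", "measured", "known", "first", "only" and "open" are said of these compounds alone.

In a functional assay on HeLa cells (Homo sapiens) for antiproliferative activity, read by MTT assay, with a stated time of 48 h (a higher number here means a weaker inhibitor, a lower number a stronger inhibitor), the measured compounds read as follows:
compound 1 `Fc1ccc(-c2nn(-c3ccccc3)cc2-c2nc3cc(C(F)(F)F)ccc3[nH]2)cc1` gives 3520 nM
compound 2 `COc1ccc(-c2nn(-c3ccccc3)cc2-c2nc3cc(F)ccc3[nH]2)cc1` gives 1740 nM
compound 3 `COc1ccc(-c2nn(-c3ccccc3)cc2-c2nc3cc(Cl)ccc3[nH]2)cc1` gives 1290 nM

Compound 3 (1290 nM) lies within the scatter of compound 2 in this assay and has a lower number than compound 1 (3520 nM). Compound 4 `COc1ccc(-c2nn(-c3ccccc3)cc2-c2nc3cc(C(F)(F)F)ccc3[nH]2)cc1` carries trifluoromethyl in place of chloro on an aromatic carbon. Going by the values given here, the one measured exchange on this carbon, chloro in place of fluoro, was small (a 1.3-fold lower number from compound 2 to compound 3 (0.13 log units; within the scatter)). Differing elsewhere from compound 4, compound 1 also bears trifluoromethyl and gives 3520 nM here, so a modest rise in the number is expected. The expected step is small (a 1.4-fold higher number from compound 3 to compound 4 (0.14 log units; within the scatter)) and may stay within the scatter. Compound 4 is estimated at 1800 nM (range 800 nM to 4000 nM).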

Compound 4, half-maximal inhibitory concentration: 2760 nM
Compound 4: the middle estimate sits 1.5-fold (0.19 log units) below what was measured; low and high end bracket the measured number.
By their numbers in this assay, from the lowest: compounds 3, 2, 4 and 1 (each within the scatter of the next, the first and the last beyond it).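

In this assay, going by these compounds alone, trifluoromethyl in place of chloro gives a 2.1-fold higher number from compound 3 to compound 4 (0.33 log units; beyond the scatter) and is the first exchange on this carbon to pass the scatter. Trifluoromethyl in place of fluoro gives a 1.6-fold higher number from compound 2 to compound 4 (0.20 log units; within the scatter) and stays within it, so only the step from chloro separates the groups at this position. With trifluoromethyl held, methoxy in place of fluoro on the other aromatic carbon gives a 1.3-fold lower number from compound 1 to compound 4 (0.11 log units; within the scatter) and also stays within the scatter.

Going by these compounds, how an amine or a carboxylic acid on this carbon would read remains open. No evidence shown here accounts for the step from chloro to trifluoromethyl.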